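Removing the 2-Carboxyethyl Chain From an Inactive Lactone Core

The source may hold more compounds than are shown below. What is called first, only, known or untested is meant among the compounds shown, and "the series" means these compounds.

Three close relatives of one fused core have been tested in an ADME assay on McCoy cells (Mus musculus) for antiproliferative activity, read by sulforhodamine B assay, with a stated time of 48 h; a lower number here means a stronger inhibitor, a higher number a weaker inhibitor. Compound 1 `C[C@H]1N=C2C[C@H]3C[C@H](C3(C)C)[C@@]2(C)OC1=O` gives > 1800000 nM, which is a limit of the assay rather than a number. Compound 2 `CC1(C)[C@@H]2CC3=NCC(=O)O[C@@]3(C)[C@H]1C2` gives > 900000 nM, again a limit. Compound 3 `CC1(C)[C@H]2CC3=N[C@H](CCC(=O)O)C(=O)O[C@]3(C)[C@@H]1C2` gives > 1200000 nM, also a limit. Compound 3 therefore stands nowhere in particular among the numbers shown: every value is a limit, recorded as the limit of > 1200000 nM in this assay, at which 1 of the 3 values shown sits, the limit of > 1800000 nM in this assay, at which 1 of the 3 values shown sits, and (the limit of > 900000 nM in this assay, at which 1 of the 3 values shown sits), so none of the three compounds can be called stronger or weaker than another in this assay. Among the measured compounds shown here, the only step between measured compounds, a step that the two limits leave unreadable from compound 1 to compound 3, cannot be sized for the same reason.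

Compound 4 `CC1(C)[C@H]2CC3=NCC(=O)O[C@]3(C)[C@@H]1C2` is compound 3 with one change: hydrogen in place of 2-carboxyethyl on a saturated ring carbon. For the measured compounds named here, no measured step bears readably on this change, and no shift beyond the scatter is expected in this assay. Compound 4 is expected to give a limit again, estimated at 1200000 nM with a range of 300000 nM to 4000000 nM. The expected step is therefore a number no higher from compound 3 to compound 4 (the limit leaves the size open).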

Compound 4, half-maximal inhibitory concentration: > 2000000 nM
Compound 4 ended at the assay's limit; the forecaster's own chance of this, stated with the estimate: 90%; at least 1.6-fold (0.22 log units) between middle value and limit.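

Compound 1, compound 2, compound 3 and compound 4 all end at limits in this assay, so the steps to compound 4 cannot be read. The compounds shown leave open whether losing 2-carboxyethyl, losing methyl or inverting every stereocentre changes activity at all.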